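Swapping a Pyridine Ring for a Propyl Chain

The compounds below may be only part of what the source reports. "The series", "measured", "known", "first", "only" and "open" are said of these compounds alone.

Three related compounds have been tested in an assay on HEK293 cells for agonist activity at transient receptor potential cation channel subfamily M member 8 (Homo sapiens), read by fluorescence and calcium flux, with a stated time of 15 min; on this read-out lower numbers stand for an effect already at smaller amounts and higher numbers for an effect only at larger amounts of compound. Compound 1 `Cc1ccc(OCC(=O)N(Cc2cccs2)c2c[nH]nc2C)cc1` gives 0.4 nM. Compound 2 `Cc1ccc(OCC(=O)N(Cc2cccs2)c2ccncc2)cc1` gives 52 nM, and compound 3 `Cc1ccc(OCC(=O)N(Cc2cccs2)c2ccccn2)cc1` gives 200 nM. Compound 3 thus carries the highest number of the three: the step of a 3.8-fold higher number from compound 2 to compound 3 (0.59 log units; beyond the scatter) separates it from its nearest neighbour, and the step of a 500-fold higher number from compound 1 to compound 3 (2.70 log units; beyond the scatter) from the furthest. Compound 2 also sits far above compound 1, as the step of a 130-fold higher number from compound 1 to compound 2 (2.11 log units; beyond the scatter) shows, so the two pyridin-yl compounds lie well apart from the pyrazolyl one.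

Compound 4 `CCCN(Cc1cccs1)C(=O)COc1ccc(C)cc1` has not yet been measured. It differs from compound 3 in one place: propyl in place of pyridin-2-yl on an amide-type nitrogen. Within the data shown here, every measured compound carries a ring on that amide-type nitrogen, and no measured step exchanges a ring for a chain, so the known steps give only indirect guidance. What they do show is that the group on this nitrogen moves the number strongly, with large steps between different rings. A change from a ring to a short chain is therefore expected to shift the number as well, most likely upward, though its size is uncertain. The expected step is a 5.0-fold higher number from compound 3 to compound 4 (0.70 log units; beyond the scatter). Compound 4 is estimated at 1000 nM, with a range from 150 nM to 10000 nM.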

Compound 4, half-maximal effective concentration: 40 nM
Compound 4: middle estimate off by 25-fold (1.40 log units), on the high side; measured number outside the range, below it.
By their numbers in this assay, from the lowest: compound 1; then compounds 4 and 2 (each within the scatter of the next); then compound 3.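

Replacing pyridin-2-yl with propyl gives a 5.0-fold lower number from compound 3 to compound 4 (0.70 log units; beyond the scatter) in this assay, so among these compounds a ring on the amide-type nitrogen is not needed for an effect at low amounts, and a short chain with no ring and no hydrogen-bond acceptor can do better than one particular ring. The chain also cannot be told apart from pyridin-4-yl, with a 1.3-fold lower number from compound 2 to compound 4 (0.11 log units; within the scatter), whereas 3-methyl-1H-pyrazol-4-yl remains clearly different, with a 100-fold higher number from compound 1 to compound 4 (2.00 log units; beyond the scatter), so at this position the pyrazolyl group stands out from the chain, while the two pyridine rings do not both fall on the same side of it. Nothing measured here explains why these groups differ.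

Going by these compounds, it remains open how the number responds to chain length, for instance whether an ethyl or a butyl chain would stay close to compound 4 or move towards compound 1. On these data alone, it is also open whether a cyclopropyl ring, or a propyl chain ending in an amine or a carboxylic acid, would be tolerated on this nitrogen.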